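A few compounds are considered here, and "the series" means these few. Any claim that something is new, unique, unknown or untested is made for them only; others in the source may bear on it.

Measured in a functional assay (HSMC cells, Homo sapiens) for antiproliferative activity, with a stated time of 72 h; on this read-out lower numbers stand for stronger inhibition and higher numbers for weaker inhibition:
compound 1 `COC(=O)[C@H](CCSC)NC(=O)c1ccc(OC[C@@H]2COc3ccccc3O2)cc1-c1ccccc1OC` gives 204000 nM
compound 2 `COC(=O)CNC(=O)c1ccc(OC[C@@H]2COc3ccccc3O2)cc1-c1ccccc1OC` gives 35000 nM
compound 3 `COC(=O)[C@H](CC(C)C)NC(=O)c1ccc(OC[C@H]2COc3ccccc3O2)cc1-c1ccccc1OC` gives 32000 nM

Compound 3 stands at the low end of the three numbers, with compound 2 within the scatter of it and only compound 1 clearly beyond. For the measured compounds named here, the single one-point step in the set, a 5.8-fold lower number from compound 1 to compound 2 (0.77 log units; beyond the scatter), concerns the side chain on the amide-bearing carbon, not the ring. Compound 4 `COC(=O)[C@H](CC(C)C)NC(=O)c1ccc(OC[C@@H]2COc3ccccc3O2)cc1-c1ccccc1OC` differs from compound 3 only in that (the two compounds have the same atoms and bonds and differ only in configuration as drawn: 1 of 2 stereo elements differ; a stereocentre at a saturated ring carbon is drawn S in compound 3 and R in compound 4). Going by the values given here, no measured step bears on this ring stereocentre; compounds 1 and 2 carry the configuration drawn for compound 4 there, but their side chains differ from that of compound 3, so they give no clean read on the inversion. For compound 4 the expected step is no change at the digits printed from compound 3 to compound 4 (within the scatter), nothing beyond the scatter in either direction. The estimate for compound 4 is 32000 nM, with a range of 10000 nM to 100000 nM.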

Compound 4, half-maximal inhibitory concentration: 17000 nM
Estimate against measurement, compound 4: 1.9-fold (0.27 log units) above; measured number inside the range.
By their numbers in this assay, from the lowest: compounds 4, 3 and 2 (each within the scatter of the next, the first and the last beyond it); then compound 1.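

With the side chain held, the ring stereocentre now has a direct read in this assay (a 1.9-fold lower number from compound 3 to compound 4 (0.27 log units; within the scatter)), so the inversion from S to R shows no shift beyond the scatter, and the comparison is clean: the fact that compounds 3 and 4 differ only in the configuration as drawn
With the R configuration held, the side chain carries the clearer steps: isobutyl in place of hydrogen gives a modest one (a 2.1-fold lower number from compound 2 to compound 4 (0.31 log units; beyond the scatter)), and isopropyl in place of (methylsulfanyl)methyl gives a large one (a 12-fold lower number from compound 1 to compound 4 (1.08 log units; beyond the scatter)).

Going by these compounds, whether the inversion reads the same with other side chains stays open. So does the effect of a carboxylic acid in place of the methyl ester or of an amine on the side chain.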